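Ethyl to cyclohexyl on the benzylic carbon of compound 1

A few compounds are considered here, and "the series" means these few. Any claim that something is new, unique, unknown or untested is made for them only; others in the source may bear on it.

Compound 1 `CC[C@@H](CCn1cncn1)c1ccccc1` is measured in an ADME assay on HEp-2 cells (Homo sapiens) for cytotoxicity, read by MTT assay, with a stated time of 3 days (a lower number here means that less compound is tolerated, a higher number that more compound is tolerated), and gives 89.9 ug/mL. Compound 2 `CC[C@@H](CCn1cncn1)c1ccc(F)cc1` gives 90.3 ug/mL in this assay, and the step of a 1.0-fold higher number from compound 1 to compound 2 (0.00 log units; within the scatter) is within the scatter, so compound 1 and compound 2 stand together on the numbers in hand, with nothing to separate them.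

Compound 3 `c1ccc([C@H](CCn2cncn2)C2CCCCC2)cc1` is not yet measured. It differs from compound 1 by cyclohexyl in place of ethyl on a saturated chain carbon bound to an aromatic carbon and a saturated chain carbon. Going by the values given here, the one measured step, a 1.0-fold higher number from compound 1 to compound 2 (0.00 log units; within the scatter), concerns a change on the aromatic ring and says nothing about an exchange at the saturated chain carbon, so no measured step bears on this change, and the series gives no guide to its size.

For compound 3 a moderate shift toward a lower number in this assay is expected, a 1.5-fold lower number from compound 1 to compound 3 (0.18 log units; within the scatter), with wide uncertainty. Compound 3 is estimated at 60 ug/mL, within a range from 25 ug/mL to 130 ug/mL.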

Compound 3, half-maximal cytotoxic concentration: 24.8 ug/mL
The estimate for compound 3 lay 2.4-fold (0.38 log units) above the measured number, outside the stated range (below it).
By their numbers in this assay, from the lowest: compound 3; then compounds 1 and 2 (each within the scatter of the next).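

The saturated chain carbon bound to an aromatic carbon and a saturated chain carbon is the first place among the compounds shown where a change registers in this assay. Cyclohexyl in place of ethyl there gives a 3.6-fold lower number from compound 1 to compound 3 (0.56 log units; beyond the scatter) and so separates compound 3 from compound 1, whereas the fluoro exchange on the aromatic ring, a 1.0-fold higher number from compound 1 to compound 2 (0.00 log units; within the scatter) in the same assay, separated nothing. No supporting measurement bears on this step, so its origin remains unassigned.

On these data alone, it remains open whether the ring itself matters at this carbon or whether a longer chain there would give a similar step. Also open, as far as these compounds go, are the effect of an amine or a carboxylic acid on the cyclohexyl ring and whether the fluoro exchange would still leave the number unmoved with cyclohexyl in place.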